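The source may report more compounds than this note shows. Statements on the series, on what has been measured and on what is new or still open speak of the compounds shown alone.

Measured in a functional assay on cells (Prostatic carcinoma cell, Homo sapiens) for cytotoxicity, read by sulforhodamine B assay, with a stated time of 48 h; a lower number here means a stronger inhibitor of growth, a higher number a weaker inhibitor of growth:
- compound 1 `O=C1Nc2ccccc2C1=Cc1c(-c2ccncc2)nc2sccn12`: 1100 nM
- compound 2 `COc1ccc2c(c1)/C(=C\c1c(OC)nc3sc(C)cn13)C(=O)N2`: 380 nM
- compound 3 `COc1nc2sc(C)cn2c1/C=C1/C(=O)Nc2ccc(O)cc21`: 7590 nM

Compound 3 has the highest of these three numbers, and the gaps to compound 1 and compound 2 both lie beyond the scatter. The next compound is compound 4 `COc1nc2sc(C)cn2c1/C=C1/C(=O)Nc2ccccc21`, not yet measured in this assay. The change is hydrogen in place of hydroxy on an aromatic carbon.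

Among the measured compounds shown here, one measured step bears directly on this place: a 20-fold higher number from compound 2 to compound 3 (1.30 log units; beyond the scatter), a large step in which hydrogen replaces methyl on the oxygen. Compound 1 also has no hydroxy group and gives 1100 nM, but it differs from compound 3 elsewhere too. For the measured compounds named here, no measured step goes straight from hydroxy to hydrogen, so the size remains uncertain. A large move to a lower number is expected, probably somewhat smaller than the measured step. The estimated change is an 8.4-fold lower number from compound 3 to compound 4 (0.93 log units; beyond the scatter). The estimate for compound 4 is 900 nM, with an expected range of 250 nM to 3000 nM.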

Compound 4, concentration for 50% growth inhibition: 2090 nM
Beside the measured number, compound 4's estimate is 2.3-fold (0.37 log units) below it; measured number inside the range.
By their numbers in this assay, from the lowest: compound 2; then compounds 1 and 4 (each within the scatter of the next); then compound 3.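

In this assay, this aromatic carbon now has three substituents that can be compared on the shared core: removing hydroxy gives a 3.6-fold lower number from compound 3 to compound 4 (0.56 log units; beyond the scatter), while replacing methoxy with hydrogen gives a 5.5-fold higher number from compound 2 to compound 4 (0.74 log units; beyond the scatter). Both steps lie beyond the scatter, so the methoxy, hydrogen and hydroxy compounds rank in that order from lowest to highest number, with the unsubstituted compound 4 in the middle. The large change seen earlier on removing the methyl from the oxygen therefore splits into two parts, with methoxy lying on one side of hydrogen and hydroxy on the other, and no available data explain this order.

On these data alone, whether ethoxy, an amine or fluorine on this carbon would fall within the same span remains open. Also open, as far as these compounds go, is whether the order holds on the core of compound 1 .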